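The source may report more compounds than this note shows. Statements on the series, on what has been measured and on what is new or still open speak of the compounds shown alone.

Compound 1 `CN(C)CCn1cnnc1-c1cc(Oc2ccc(NC(=O)N/N=C/c3ccccc3)cc2F)ccn1` and compound 2 `CN(C)CCn1cnnc1-c1cc(Oc2ccc(NC(=O)N/N=C/c3ccc(O)c(O)c3)cc2F)ccn1` share one core and differ only in the ring attached to the carbon with a double bond to nitrogen. In a functional assay on U-87MG ATCC cells (Homo sapiens) for cytotoxicity, read by MTT assay, with a stated time of 72 h (on this read-out higher numbers stand for weaker inhibition and lower numbers for stronger inhibition), compound 1 gives 2250 nM. Compound 2 reaches only the limit of this assay, > 100000 nM, so no exact number is known for it. The step of an at least 44-fold higher number from compound 1 to compound 2 (1.64 log units; beyond the scatter) is therefore only a lower bound, resting on (the limit of > 100000 nM in this assay, at which 1 of the 2 values shown sits). Compound 3 `CN(C)CCn1cnnc1-c1cc(Oc2ccc(NC(=O)N/N=C/c3cccc(Br)c3)cc2F)ccn1` has not yet been measured. It differs from compound 2 by 3-bromophenyl in place of 3,4-dihydroxyphenyl on a carbon with a double bond to nitrogen. This removes the hydroxyl groups whose arrival gave the large loss seen in an at least 44-fold higher number from compound 1 to compound 2 (1.64 log units; beyond the scatter) and puts a bromine on the ring instead. Compound 3 is therefore expected to land near where compound 1 stands. The estimate for compound 3 is 2000 nM, with a range from 500 nM to 10000 nM. The expected gain an at least 50-fold lower number from compound 2 to compound 3 (1.69 log units; beyond the scatter) would lie beyond the scatter.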

Compound 3, half-maximal inhibitory concentration: 830 nM
For compound 3 the middle estimate is 2.4-fold (0.38 log units) above the measured one, and the stated range covers the measured number.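

In this assay, the ring on the carbon with a double bond to nitrogen can carry a substituent without a loss: a 2.7-fold lower number from compound 1 to compound 3 (0.43 log units; beyond the scatter) shows that adding a bromine goes with a modest gain over the bare phenyl, unlike the large loss seen with the two hydroxyl groups. Across these three compounds, what sits on this ring can therefore move the number in either direction. The swap of 3,4-dihydroxyphenyl for 3-bromophenyl gives an at least 120-fold lower number from compound 2 to compound 3 (2.08 log units; beyond the scatter), but this size is only a lower bound, since the value of compound 2 is a limit and not a number: the limit of > 100000 nM in this assay, at which 1 of the 3 values shown sits.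

The compounds shown leave open how far the outcome depends on bromine in particular. A chlorine, a methoxy group or a single hydroxyl group on the ring could behave like the bromine or like the pair of hydroxyl groups.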